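The source may report more compounds than this note shows. Statements on the series, on what has been measured and on what is new or still open speak of the compounds shown alone.

In an in vitro ADME assay on microsomes from liver (Simiiformes) (a lower number here means that the compound disappears faster, a higher number that the compound lasts longer), compound 3 `CCOc1nc(-c2cc(C)c(OCCCc3cc(C)no3)c(C)c2)no1` gives > 2.5 h, which is a limit of the assay and not a number. Compound 4 `Cc1cc(CCCOc2c(C)cc(-c3noc(C(F)F)n3)cc2C)on1` differs from it in one group: difluoromethyl in place of ethoxy on an aromatic carbon of a five-membered aromatic ring with 2 nitrogen and 1 oxygen (difluoromethyl in place of ethoxy on an aromatic carbon).

Two measured relatives carry a halogen-bearing methyl group at that same place. Compound 1 `Cc1cc(CCCOc2c(C)cc(-c3noc(CF)n3)cc2C)on1`, with fluoromethyl, gives 0.233 h. Compound 2 `Cc1cc(CCCOc2c(C)cc(-c3noc(C(Cl)(Cl)Cl)n3)cc2C)on1`, with trichloromethyl, gives 0.183 h. The swap between these two groups amounts to a 1.3-fold lower number from compound 1 to compound 2 (0.10 log units; within the scatter). Replacing either group with ethoxy made a much bigger difference, with an at least 10-fold higher number from compound 1 to compound 3 (1.03 log units; beyond the scatter) and an at least 13-fold higher number from compound 2 to compound 3 (1.13 log units; beyond the scatter), both large.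

Difluoromethyl is also a halogen-bearing methyl group, so the present swap should act as the reverse of those two steps, and a large fall in half-life is expected. The expected change is an at least 8.9-fold lower number from compound 3 to compound 4 (0.95 log units; beyond the scatter). The estimate for compound 4 is 0.28 h, with an expected range from 0.12 h to 0.8 h.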

Compound 4, half-life: 1.42 h
Compound 4: the middle estimate sits 5.1-fold (0.71 log units) below what was measured; the whole stated range lies below it.
By their numbers in this assay, from the lowest: compounds 2 and 1 (each within the scatter of the next); then compound 4. At a limit, above all of these: compound 3.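

At this place on the ring, a halogen-bearing methyl group does not by itself bring a short half-life in this assay: difluoromethyl in place of trichloromethyl gives a 7.8-fold higher number from compound 2 to compound 4 (0.89 log units; beyond the scatter). Fluoro in place of hydrogen therefore counts here, with a 6.1-fold higher number from compound 1 to compound 4 (0.78 log units; beyond the scatter), even though the swap between the two earlier groups gave a 1.3-fold lower number from compound 1 to compound 2 (0.10 log units; within the scatter). Compound 3 stands at a limit and not a number, so an at least 1.7-fold lower number from compound 3 to compound 4 (0.24 log units; that floor lies within the scatter) gives only a floor, and how far difluoromethyl falls short of ethoxy stays unknown: the limit of > 2.5 h in this assay, at which 1 of the 4 values shown sits.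

The compounds shown leave open where trifluoromethyl would fall, and so whether half-life follows the number of fluorines on that carbon. They also leave open whether methoxy or a longer alkoxy chain would last as long as ethoxy.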